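The source may report more compounds than this note shows. Statements on the series, on what has been measured and on what is new or still open speak of the compounds shown alone.

Compound 3 `CC[C@@H](Nc1c(C#N)c(-c2ccc(-c3ccc(OC)cc3)cc2)nc2cnccc12)C(N)=O` stands second highest of the three measured values in a physicochemical assay for lipophilicity, read by HPLC, at pH 7.5 (on this read-out higher numbers stand for higher lipophilicity and lower numbers for lower lipophilicity), where compound 3 gives 2.7; compound 1 `CC[C@@H](Nc1c(C#N)c(-c2ccc(-c3ncccc3C)cc2)nc2cnccc12)C(N)=O` gives 2 and compound 2 `CCOc1ccccc1-c1ccc(-c2nc3cncc(Cl)c3c(N[C@H](CC)C(N)=O)c2C#N)cc1` gives 3.7. For the measured compounds named here, the only single-point step among them, a number 0.70 log units higher from compound 1 to compound 3 (beyond the scatter), is modest yet beyond the scatter. Compound 4 `CCOc1ccccc1-c1ccc(-c2nc3cnccc3c(N[C@H](CC)C(N)=O)c2C#N)cc1` differs from compound 3 in one place: 2-ethoxyphenyl in place of 4-methoxyphenyl on an aromatic carbon. Going by the values given here, no measured step covers the same change, but compound 2 also carries a 2-ethoxyphenyl and sits higher than compound 3, although compound 2 differs from compound 4 in a second place as well. A modest rise is therefore expected, a number 0.40 log units higher from compound 3 to compound 4 (beyond the scatter), and compound 4 is estimated at 3.1, with a range from 2.7 to 3.5.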

Compound 4, distribution coefficient: 3
Beside the measured number, compound 4's estimate is 0.10 log units above it, within the range that was stated.
By their numbers in this assay, from the lowest: compound 1; then compounds 3 and 4 (each within the scatter of the next); then compound 2.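

In this assay the swap of 4-methoxyphenyl for 2-ethoxyphenyl gives a number 0.30 log units higher from compound 3 to compound 4 (within the scatter) and so does not separate the two groups, whereas 2-ethoxyphenyl in place of 3-methylpyridin-2-yl gives a number 1.00 log units higher from compound 1 to compound 4 (beyond the scatter) on the same position. With 2-ethoxyphenyl held fixed, the change on the core gives a number 0.70 log units lower from compound 2 to compound 4 (beyond the scatter) and shows that hydrogen in place of chloro also moves the number. No evidence at hand explains these steps. On these data alone, whether the chloro step holds with the other two groups stays open, and so does the effect of an amine or a carboxylic acid at this position.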